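Cyano on the fused ring of compound 1

A few compounds are considered here, and "the series" means these few. Any claim that something is new, unique, unknown or untested is made for them only; others in the source may bear on it.

Measured compounds:
compound 1 `CN(C(=O)c1ccccc1)c1ccc2[nH]c(-c3n[nH]c4ccccc34)cc2n1`: 8580 nM
compound 2 `COc1cccc(C(=O)N(C)c2ccc3[nH]c(-c4n[nH]c5ccccc45)cc3n2)c1`: 9010 nM

In a functional assay on KB cells (Homo sapiens) for antiproliferative activity, read by MTT assay, with a stated time of 72 h (on this read-out higher numbers stand for weaker inhibition and lower numbers for stronger inhibition), compound 1 gives 8580 nM, the lowest of the two numbers, with compound 2 nearest to it. Compound 2 gives 9010 nM. Among the compounds with values here, the only measured step, a 1.1-fold higher number from compound 1 to compound 2 (0.02 log units; within the scatter), comes from a methoxy in place of hydrogen on an aromatic carbon and stays within the scatter.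

Compound 3 `CN(C(=O)c1ccccc1)c1ccc2[nH]c(-c3n[nH]c4cc(C#N)ccc34)cc2n1` differs from compound 1 by cyano in place of hydrogen on an aromatic carbon. Within the data shown here, no measured step touches this ring; the one step at hand concerns a different aromatic carbon of the shared core and showed no movement beyond the scatter. On that basis no step beyond the scatter is expected for compound 3 in this assay, that is, roughly a 1.1-fold lower number from compound 1 to compound 3 (0.06 log units; within the scatter). The estimate for compound 3 is 7500 nM, with a range from 2500 nM to 22000 nM.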

Compound 3, half-maximal inhibitory concentration: 20900 nM
Compound 3: middle estimate off by 2.8-fold (0.45 log units), on the low side; the measured number falls inside the stated range.
By their numbers in this assay, from the lowest: compounds 1 and 2 (each within the scatter of the next); then compound 3.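

In this assay, the six-membered aromatic ring of carbon only, part of a fused system of two rings, proves sensitive to substitution: cyano in place of hydrogen gives a 2.4-fold higher number from compound 1 to compound 3 (0.39 log units; beyond the scatter), a modest shift towards weaker inhibition. The earlier methoxy change, at a different aromatic carbon, gave a 1.1-fold higher number from compound 1 to compound 2 (0.02 log units; within the scatter), so the series now holds one change that stays within the scatter and one that goes beyond it. No measurement at hand bears on why this cyano step moves the number.

With one substituent at this carbon, the compounds shown leave open whether the loss belongs to cyano itself or to any group placed there. An amine or a carboxylic acid on the same carbon would help separate these two readings.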